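Adding a Methyl to the Amine of Compound 2

The source may report more compounds than this note shows. Statements on the series, on what has been measured and on what is new or still open speak of the compounds shown alone.

Of the compounds shown here, three sharing one core have been tested in an assay on CHO cells with 5-hydroxytryptamine receptor 1D (Homo sapiens) as the target; on this read-out higher numbers stand for weaker inhibition and lower numbers for stronger inhibition. Compound 1 `CN(CC(C)(C)C)CC1(O)CCN(CCCc2c[nH]c3ccc(-n4cnnc4)cc23)CC1` gives 1.8 nM, compound 2 `Cc1ccccc1CNCC1(O)CCN(CCCc2c[nH]c3ccc(-n4cnnc4)cc23)CC1` gives 4 nM, and compound 3 `CC(=O)Nc1ccc(CNCC2(O)CCN(CCCc3c[nH]c4ccc(-n5cnnc5)cc34)CC2)cc1` gives 11 nM. Compound 2 thus stands second highest of the three numbers: the step of a 2.2-fold higher number from compound 1 to compound 2 (0.35 log units; beyond the scatter) places it above compound 1, while the step of a 2.8-fold higher number from compound 2 to compound 3 (0.44 log units; beyond the scatter) places it below compound 3. Compound 4 `Cc1ccccc1CN(C)CC1(O)CCN(CCCc2c[nH]c3ccc(-n4cnnc4)cc23)CC1` is the compound that follows, and it differs from compound 2 in a single place: methyl in place of hydrogen on an amine nitrogen.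

For the measured compounds named here, no measured step exchanges only this hydrogen for a methyl. The closest comparison is compound 1, whose methyl(neopentyl)amino group already carries a methyl on the amine nitrogen; the step of a 2.2-fold higher number from compound 1 to compound 2 (0.35 log units; beyond the scatter) shows that replacing that group with (2-methylbenzyl)amino gave a modestly higher number, yet that step also replaces neopentyl with 2-methylbenzyl, so its two parts cannot be separated. The step of a 6.1-fold higher number from compound 1 to compound 3 (0.79 log units; beyond the scatter) has the same double nature. The expectation is therefore a small step, most likely toward a lower number, a 1.3-fold lower number from compound 2 to compound 4 (0.12 log units; within the scatter). Compound 4 is estimated at 3 nM, within a range from 1.2 nM to 8 nM.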

Compound 4, half-maximal inhibitory concentration: 1.3 nM
Estimate against measurement, compound 4: 2.3-fold (0.36 log units) above; the range from low to high includes it.
By their numbers in this assay, from the lowest: compounds 4 and 1 (each within the scatter of the next); then compound 2; then compound 3.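

In this assay, for the compounds shown here, the step of a 3.1-fold lower number from compound 2 to compound 4 (0.49 log units; beyond the scatter) is the first to isolate the methyl on the amine nitrogen, showing that this one added carbon, in place of a hydrogen, lowers the number by itself. With that methyl present on both compounds, the step of a 1.4-fold lower number from compound 1 to compound 4 (0.14 log units; within the scatter), with 2-methylphenyl in place of tert-butyl, stays within the scatter, so at this point in the series the two groups cannot be told apart on this read-out. The step of an 8.5-fold lower number from compound 3 to compound 4 (0.93 log units; beyond the scatter) still combines the added methyl with a change in the benzyl group, so its size cannot be divided between the two, and no measurement available here explains why the methyl lowers the number.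

From the compounds shown here alone, it remains open whether the same methyl would lower the number when the amine carries 4-acetamidobenzyl, or when it carries neopentyl, since the gain seen here comes from the 2-methylbenzyl pair alone. Going by these compounds, it is also open whether a longer chain on the amine nitrogen, such as ethyl or propyl, would match the methyl or give up its gain.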